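Changing One Side Chain on an Inactive Compound

The source may report more compounds than this note shows. Statements on the series, on what has been measured and on what is new or still open speak of the compounds shown alone.

In a functional assay on DU-145 cells (Homo sapiens) for cytotoxicity, read by sulforhodamine B assay (on this read-out lower numbers stand for stronger inhibition of growth and higher numbers for weaker inhibition of growth), compound 2 `CCOC(=O)/C(C#N)=C/c1ccccc1-c1c(C(=O)OC)cc(OC)c(OC)c1OC` gives > 40000 nM, which is a limit of the assay and not a number. Compound 3 `COC(=O)c1cc(OC)c(OC)c(OC)c1-c1ccccc1C=C(C#N)C#N` differs from compound 2 in one place: 2,2-dicyanoethenyl in place of 2-cyano-2-(ethoxycarbonyl)ethenyl on an aromatic carbon. Put simply, it has 2,2-dicyanoethenyl in place of 2-cyano-2-(ethoxycarbonyl)ethenyl on an aromatic carbon. Compound 1 `COc1cc(C=C(C#N)C#N)c(-c2ccccc2C=C(C#N)C#N)c(OC)c1OC` also carries 2,2-dicyanoethenyl, and compound 1 gives > 40000 nM, again only a limit. So no step beyond the usual scatter, in either direction, is expected in this assay, and the estimated change is an at least 1.1-fold lower number from compound 2 to compound 3 (0.05 log units; that floor lies within the scatter). Compound 3 is estimated at 35000 nM, with an expected range of 10000 nM to 40000 nM.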

Compound 3, concentration for 50% growth inhibition: 21900 nM
For compound 3 the middle estimate is 1.6-fold (0.20 log units) above the measured one; measured number inside the range.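

For the compounds shown here, compound 3 is the first compound here to give a true number rather than a limit in this assay. Placing 2,2-dicyanoethenyl on this aromatic carbon gives an at least 1.8-fold lower number from compound 2 to compound 3 (0.26 log units; that floor lies within the scatter), and methoxycarbonyl in place of 2,2-dicyanoethenyl gives an at least 1.8-fold lower number from compound 1 to compound 3 (0.26 log units; that floor lies within the scatter), so neither change can yet be called a real gain. Both steps start from the same ceiling: the limit of > 40000 nM in this assay, at which 2 of the 3 values shown sit.

Going by these compounds, the true distance of compound 1 and compound 2 from compound 3 remains open. So does whether a carboxylic acid or an amine at this position would shift the number beyond the scatter.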